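Benzyl(propyl)amino variant of a steryl-sulfatase sulfamate

The compounds below may be only part of what the source reports. "The series", "measured", "known", "first", "only" and "open" are said of these compounds alone.

Measured compounds:
compound 1, `CN(C)CCCN(Cc1ccccc1)c1cccc(C(=O)N2CCc3ccc(OS(N)(=O)=O)cc3C2)c1`, 23.8%
compound 2, `CCN(Cc1cccc(Br)c1)c1cccc(C(=O)N2CCc3ccc(OS(N)(=O)=O)cc3C2)c1`, 20.9%

Of the compounds shown here, two sharing one core have been tested in an assay on HEK293 cells for inhibition of Steryl-sulfatase (Homo sapiens), tested at 0.1 uM; on this read-out lower numbers stand for a weaker effect and higher numbers for a stronger effect at the one concentration tested. Compound 1, `CN(C)CCCN(Cc1ccccc1)c1cccc(C(=O)N2CCc3ccc(OS(N)(=O)=O)cc3C2)c1`, gives 23.8%. Compound 2, `CCN(Cc1cccc(Br)c1)c1cccc(C(=O)N2CCc3ccc(OS(N)(=O)=O)cc3C2)c1`, gives 20.9%. The two numbers lie within the scatter of each other, so compound 2 stands together with compound 1 on this read-out and neither can be set apart from the other.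

Compound 3, `CCCN(Cc1ccccc1)c1cccc(C(=O)N2CCc3ccc(OS(N)(=O)=O)cc3C2)c1`, has not yet been measured in this assay. It differs from compound 2 in one place: benzyl(propyl)amino in place of (3-bromobenzyl)(ethyl)amino on an aromatic carbon. Both amino groups carry a benzyl part and a short chain and have the same count of heavy atoms and of hydrogen-bond acceptors. Among the compounds with values here, with only two measured compounds and no step between them that rises above the scatter, there is no basis for expecting a step of any size in this assay. The step from compound 2 to compound 3 is therefore expected to stay within the scatter, which is what a number 0.1 percentage points higher from compound 2 to compound 3 (within the scatter) means. Compound 3 is thus estimated at 21%, with a range from 8% to 34%.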

Compound 3, a percentage reported as inhibition, at one concentration (the size of the read-out at that concentration, not a potency): 23.1%
Beside the measured number, compound 3's estimate is 2.1 percentage points below it; the measured number falls inside the stated range.
By their numbers in this assay, from the lowest: compounds 2, 3 and 1 (each within the scatter of the next).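

On an aromatic carbon, meta to a large group, exchanging (3-bromobenzyl)(ethyl)amino for benzyl(propyl)amino gives a number 2.2 percentage points higher from compound 2 to compound 3 (within the scatter) in this assay and so leaves the read-out unresolved at the one concentration tested, even though this single exchange both removes the bromine and changes the short chain. Compound 3 also provides the first comparison of the chain end, where hydrogen in place of dimethylamino gives a number 0.7 percentage points lower from compound 1 to compound 3 (within the scatter) and shows that, among these compounds, having dimethylamino on the saturated chain or not makes no difference that can be read. Nothing available bears on why the three compounds sit together on this read-out.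

The compounds shown do not separate the bromine from the chain length, since no pair among them changes only one of the two, and they leave open whether the parts of the amino group that were exchanged could move the read-out at all. As far as these compounds go, whether a carboxylic acid or a hydroxyl at the chain end, a longer chain such as hexyl, or a chlorine on the benzyl ring would yield a step beyond the scatter remains unknown.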